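A few compounds are considered here, and "the series" means these few. Any claim that something is new, unique, unknown or untested is made for them only; others in the source may bear on it.

Of the compounds shown here, three built on one shared core have been measured in an assay on isolated protein for binding affinity to Rap guanine nucleotide exchange factor 4 (Homo sapiens), read by cAMP accumulation; on this read-out lower numbers stand for stronger inhibition and higher numbers for weaker inhibition. Compound 1 `Cc1cc(C)c(Nc2cccc(F)c2)c(C)c1` gives 5800 nM. Compound 2 `CCc1cccc(Nc2c(C)cc(C)cc2C)c1` gives 1800 nM, and compound 3 `Cc1cc(C)c(Nc2cccc(C(F)(F)F)c2)c(C)c1` gives 2000 nM. Among these three, compound 3 stands second highest: its number lies within the scatter of that of compound 2, while the step of a 2.9-fold lower number from compound 1 to compound 3 (0.46 log units; beyond the scatter) sets it well apart from compound 1.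

Compound 4 `Cc1cc(C)c(Nc2cccc(N)c2)c(C)c1` differs from compound 3 in one place: amino in place of trifluoromethyl on an aromatic carbon, on an aromatic carbon of a six-membered aromatic ring of carbon only, meta to a large group. Among the measured compounds shown here, no measured step exchanges trifluoromethyl for amino directly. For the measured compounds named here, the steps that bear on the question are a 3.2-fold lower number from compound 1 to compound 2 (0.51 log units; beyond the scatter) and a 2.9-fold lower number from compound 1 to compound 3 (0.46 log units; beyond the scatter), in which replacing fluoro by ethyl or by trifluoromethyl lowered the number, whereas a 1.1-fold higher number from compound 2 to compound 3 (0.05 log units; within the scatter) stayed within the scatter. Compound 1, the fluoro compound, gives the highest number of the three, and the change to amino is expected to move compound 4 back toward it, a step of a 2.0-fold higher number from compound 3 to compound 4 (0.30 log units; within the scatter). Compound 4 is therefore estimated at 4000 nM, with a likely range from 1500 nM to 12000 nM.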

Compound 4, half-maximal inhibitory concentration: 34000 nM
Compound 4: middle estimate off by 8.5-fold (0.93 log units), on the low side; the whole stated range lies below it.
By their numbers in this assay, from the lowest: compounds 2 and 3 (each within the scatter of the next); then compound 1; then compound 4.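

At this position, the choice of group matters far more than the first three compounds suggested. Ethyl and trifluoromethyl gave numbers within the scatter of each other, but amino brings large steps from both (a 17-fold higher number from compound 3 to compound 4 (1.23 log units; beyond the scatter); a 19-fold higher number from compound 2 to compound 4 (1.28 log units; beyond the scatter)), and it also goes past fluoro, the previous highest number (a 5.9-fold higher number from compound 1 to compound 4 (0.77 log units; beyond the scatter)), which makes compound 4 the weakest of the four. Amino, unlike the trifluoromethyl it replaces, counts a hydrogen-bond donor and acceptor, but no measurement shown explains the loss.

Still open, from the compounds shown here alone, is whether the high number belongs to amino alone or would also appear with a hydroxyl, a methoxy or a dimethylamino group here. Also open, going by these compounds, is whether a chain longer than ethyl would lower the number further.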